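The compounds below may be only part of what the source reports. "The series", "measured", "known", "first", "only" and "open" are said of these compounds alone.

The measured compounds are compound 1 `O=C(Nc1ccc(F)cc1)Nc1nc(-c2cc3ccccc3o2)cs1` with 1130 nM, compound 2 `COc1ccc(NC(=O)Nc2nc(-c3cc4cc([N+](=O)[O-])ccc4o3)cs2)cc1` with 121000 nM, and compound 3 `O=C(Nc1ccc(Cl)cc1)Nc1nc(-c2cc3cc([N+](=O)[O-])ccc3o2)cs1` with 117000 nM, all in a physicochemical assay, with a stated time of 6 min; a lower number here means a stronger inhibitor, a higher number a weaker inhibitor.

Compound 1 gives the lowest number of the three, far apart from compound 2 and compound 3. Compound 4 `Cc1ccc(NC(=O)Nc2nc(-c3cc4ccccc4o3)cs2)cc1` differs from compound 1 by methyl in place of fluoro on an aromatic carbon. Among the measured compounds shown here, no measured step matches this change exactly; the only step between measured compounds, a 1.0-fold lower number from compound 2 to compound 3 (0.01 log units; within the scatter), swaps one group for another on the same six-membered ring and stays within the scatter, which hints that such swaps on this ring change little. The step from compound 1 to compound 4 in this assay is therefore expected to be small, a 1.0-fold lower number from compound 1 to compound 4 (0.01 log units; within the scatter), and compound 4 is estimated at 1100 nM, between 400 nM and 3200 nM.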

Compound 4, half-maximal inhibitory concentration: 500 nM
Beside the measured number, compound 4's estimate is 2.2-fold (0.34 log units) above it; low and high end bracket the measured number.
By their numbers in this assay, from the lowest: compound 4; then compound 1; then compounds 3 and 2 (each within the scatter of the next).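

In this assay the change to methyl gives a 2.3-fold lower number from compound 1 to compound 4 (0.35 log units; beyond the scatter) and so shows that a swap at this ring carbon can move the number beyond the scatter, though only modestly. The earlier step, a 1.0-fold lower number from compound 2 to compound 3 (0.01 log units; within the scatter), stayed within the scatter, but it involved different groups on a different core. Nothing measured here explains the shift.
Still open, from the compounds shown here alone, is how an amine, a carboxylic acid or a longer chain would fare at this place. Also open, going by these compounds, is whether methoxy or chloro would behave the same on the core of compound 1.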